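This account rests on a few compounds, and the source may have more. Where it says the series, first, only, none or still open, it means among the compounds named here.

Three compounds with a shared core carrying a nitrophenyl group have been run in an ADME assay on Vero cells (Chlorocebus sabaeus) for cytotoxicity, read by MTT assay, with a stated time of 72 h; on this read-out lower numbers stand for stronger inhibition and higher numbers for weaker inhibition. Compound 1 `O=C(Nc1nnc(-c2ccc([N+](=O)[O-])cc2)s1)c1ccco1` gives 306000 nM there, compound 2 `Cc1ccc(C(=O)Nc2nnc(-c3ccc([N+](=O)[O-])cc3)s2)cc1` gives 310000 nM, and compound 3 `CCCCC(=O)Nc1nnc(-c2cccc([N+](=O)[O-])c2)s1` gives 289000 nM. Within the data shown here, the one measured change, a 1.0-fold higher number from compound 1 to compound 2 (0.01 log units; within the scatter), shows that swapping the group on the carbonyl carbon left the read-out unmoved. Compound 3 sits within the usual scatter of both compound 1 and compound 2, so the three numbers cannot be told apart on this read-out.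

Compound 4 `O=C(Nc1nnc(-c2cccc([N+](=O)[O-])c2)s1)c1ccco1` is not yet measured. It differs from compound 3 in one place: furan-2-yl in place of butyl on a carbonyl carbon. Among the measured compounds shown here, no measured step exchanges butyl for furan-2-yl; the only comparable one, a 1.0-fold higher number from compound 1 to compound 2 (0.01 log units; within the scatter), changed the same position and stayed within the scatter, and compound 1, which already carries the furan-2-yl group, sits beside compound 3. On that basis compound 4 is expected to show a 1.0-fold higher number from compound 3 to compound 4 (0.02 log units; within the scatter), that is no step beyond the scatter. Compound 4 is therefore estimated at 300000 nM in this assay, between 150000 nM and 600000 nM.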

Compound 4, half-maximal inhibitory concentration: 312000 nM
For compound 4 the middle estimate is 1.0-fold (0.02 log units) below the measured one, within the range that was stated.
By their numbers in this assay, from the lowest: compounds 3, 1, 2 and 4 (each within the scatter of the next).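

Replacing butyl with furan-2-yl on the carbonyl carbon gave a 1.1-fold higher number from compound 3 to compound 4 (0.03 log units; within the scatter) in this assay. The earlier step had exchanged one ring for another, whereas this one brings a five-membered aromatic ring and a hydrogen-bond acceptor in place of an open chain, and the read-out still stays within the scatter, here with the nitrophenyl arrangement of compound 3 rather than that of compound 1. No available evidence bears on why this position tolerates the change without a measurable shift. Going by these compounds, it remains open whether an amine, a carboxylic acid or a chain longer than butyl on this carbonyl carbon would move the number beyond the scatter. On these data alone, all four compounds carry a nitrophenyl group, so it is also open whether a plain phenyl or an aminophenyl group in its place would do so.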